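Trading Chain Length for a Double Bond

The source may report more compounds than this note shows. Statements on the series, on what has been measured and on what is new or still open speak of the compounds shown alone.

Compound 3 `CCCCCCCCCCCCCCCCCCCC(=O)O[C@H]1[C@H](O)[C@H](n2ccc(N)nc2=O)O[C@@H]1CO` gives 0.1 ug/mL in a functional assay on HeLa cells (Homo sapiens) for cytotoxicity, read by cell counting, with a stated time of 48 h; on this read-out lower numbers stand for an effect already at smaller amounts and higher numbers for an effect only at larger amounts of compound. Among the three measured compounds it holds the second highest number: compound 1 `CCCCCCCCCCCCCCCCCC(=O)O[C@H]1[C@H](O)[C@H](n2ccc(N)nc2=O)O[C@@H]1CO` gives 0.13 ug/mL, and the step of a 1.3-fold lower number from compound 1 to compound 3 (0.11 log units; within the scatter) stays within the scatter, while compound 2 `C=CCCCCCCCCC(=O)O[C@H]1[C@H](O)[C@H](n2ccc(N)nc2=O)O[C@@H]1CO` gives 0.05 ug/mL, and the step of a 2.0-fold higher number from compound 2 to compound 3 (0.30 log units; within the scatter) also stays within the scatter. Compound 4 `CCCCCCCC/C=C/CCCCCCCC(=O)O[C@H]1[C@H](O)[C@H](n2ccc(N)nc2=O)O[C@@H]1CO` differs from compound 3 by a group of 10 heavy atoms (10 carbon; no ring) in place of a group of 12 heavy atoms (12 carbon; no ring), on a saturated chain carbon, seven bonds along the chain from a carbonyl carbon. Within the data shown here, the only step beyond the scatter is a 2.6-fold lower number from compound 1 to compound 2 (0.41 log units; beyond the scatter), where a shorter chain ending in a vinyl group lowered the number modestly, whereas lengthening the chain, a 1.3-fold lower number from compound 1 to compound 3 (0.11 log units; within the scatter), changed little. A double bond within a somewhat shorter chain is therefore expected to lower the number at most modestly. Compound 4 is estimated at 0.08 ug/mL, between 0.03 ug/mL and 0.2 ug/mL, an expected step of a 1.3-fold lower number from compound 3 to compound 4 (0.10 log units; within the scatter).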

Compound 4, concentration for half-maximal effect: 0.05 ug/mL
Beside the measured number, compound 4's estimate is 1.6-fold (0.20 log units) above it; the measured number falls inside the stated range.
By their numbers in this assay, from the lowest: compounds 2, 4, 3 and 1 (each within the scatter of the next, the first and the last beyond it).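

The double bond in the chain of compound 4 leaves the number close to its neighbours: a 2.0-fold lower number from compound 3 to compound 4 (0.30 log units; within the scatter) is the step from the saturated chain of similar length, and no change at the digits printed from compound 2 to compound 4 (within the scatter) is the step from the chain with the vinyl group. Only a 2.6-fold lower number from compound 1 to compound 4 (0.41 log units; beyond the scatter) goes beyond the scatter, so a second unsaturated chain now gives a modestly lower number than compound 1, though saturated compound 3 stays within the scatter of both unsaturated compounds. Nothing measured here explains this. Going by these compounds, whether the cis double bond, a chain with two double bonds or a chain carrying an amine would behave alike stays open.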